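This account rests on a few compounds, and the source may have more. Where it says the series, first, only, none or still open, it means among the compounds named here.

In a functional assay on MCF7 cells (Homo sapiens) for antiproliferative activity, read by MTT assay, with a stated time of 48 h (on this read-out higher numbers stand for weaker inhibition and lower numbers for stronger inhibition), compound 1 `Cc1ccc(-c2cc(NC(=O)/C=C/c3ccc(Cl)cc3)n[nH]2)cc1` gives 1190 nM, within the usual scatter of compound 2 `O=C(/C=C/c1ccc(Cl)cc1)Nc1cc(-c2ccccc2)[nH]n1` at 970 nM and of compound 3 `O=C(/C=C/c1ccc([N+](=O)[O-])cc1)Nc1cc(-c2ccccc2)[nH]n1` at 630 nM. Compound 4 `Cc1ccc(-c2cc(NC(=O)/C=C/c3ccc(F)cc3)n[nH]2)cc1` keeps the core of compound 1 and makes a single change: fluoro in place of chloro on an aromatic carbon. Going by the values given here, no measured step makes this exact swap. The closest one also removes the chloro, putting nitro in its place, and shows a 1.5-fold lower number from compound 2 to compound 3 (0.19 log units; within the scatter). Replacing methyl with hydrogen on an aromatic carbon shows a 1.2-fold lower number from compound 1 to compound 2 (0.09 log units; within the scatter). Neither step leaves the scatter, so the change to fluoro is not expected to move the number beyond it. The estimated step is a 1.1-fold lower number from compound 1 to compound 4 (0.03 log units; within the scatter). For compound 4 the expected value is 1100 nM, with an estimated range from 600 nM to 2100 nM.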

Compound 4, half-maximal inhibitory concentration: 950 nM
Compound 4: the middle estimate sits 1.2-fold (0.06 log units) above what was measured; the measured number falls inside the stated range.
By their numbers in this assay, from the lowest: compounds 3, 4, 2 and 1 (each within the scatter of the next).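

In this assay, the change from 4-chlorophenyl to 4-fluorophenyl gives a 1.3-fold lower number from compound 1 to compound 4 (0.10 log units; within the scatter), so chloro and fluoro cannot be told apart at this position. The earlier compounds shown here compared only chloro with nitro here, and without the methyl group; this direct swap between two halogens, with the methyl group present, also stays within the scatter. Nothing measured here offers an explanation for this result.

All four compounds carry chloro, fluoro or nitro at this position, and all their steps stay within the scatter. As far as these compounds go, whether an amine or a carboxylic acid there would read differently remains open.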